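Alkoxy variation on the biaryl benzylamine series

The source may report more compounds than this note shows. Statements on the series, on what has been measured and on what is new or still open speak of the compounds shown alone.

Measured compounds:
- Compound 1 `Nc1ncnc2c1nc(NCc1ccc(-c3ccncc3)cc1)n2[C@@H]1O[C@H](CO)[C@@H](O)[C@H]1O`: 2700 nM
- Compound 2 `CCCOc1cc(CNc2nc3c(N)ncnc3n2[C@@H]2O[C@H](CO)[C@@H](O)[C@H]2O)ccc1-c1ccccc1`: 5200 nM
- Compound 3 `CC(C)Oc1cc(CNc2nc3c(N)ncnc3n2[C@@H]2O[C@H](CO)[C@@H](O)[C@H]2O)ccc1-c1ccccc1`: 10400 nM

In an assay on COS-7 cells for inhibition of sodium/nucleoside cotransporter 2 (Homo sapiens), read by scintillation counting (a lower number here means a stronger inhibitor, a higher number a weaker inhibitor), compound 3 gives 10400 nM, the highest number among the three compounds measured. Its nearest neighbour is compound 2, and the step of a 2.0-fold higher number from compound 2 to compound 3 (0.30 log units; within the scatter) lies within the scatter. Compound 1 gives 2700 nM, a lower number that lies beyond the scatter from compound 3; compound 1 differs from compound 3 in more than one place, so no single step can be read from that pair.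

Compound 4 `Nc1ncnc2c1nc(NCc1ccc(-c3ccccc3)c(OCCO)c1)n2[C@@H]1O[C@H](CO)[C@@H](O)[C@H]1O` is not yet measured in this assay. The change from compound 3 is 2-hydroxyethyl in place of isopropyl on an oxygen on an aromatic ring. Among the compounds with values here, the one step that bears on this position, the step of a 2.0-fold higher number from compound 2 to compound 3 (0.30 log units; within the scatter), exchanged one alkyl group for another on the same oxygen and stayed within the scatter. Within the data shown here, no measured step tells what a hydroxyl-bearing chain does at this oxygen, so the expectation rests on the observation that the alkoxy variation seen so far moved the number little. For compound 4 a step of a 1.5-fold lower number from compound 3 to compound 4 (0.17 log units; within the scatter) is expected, lying within the scatter. Compound 4 is therefore estimated at 7000 nM in this assay, with a range from 2500 nM to 20000 nM.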

Compound 4, half-maximal inhibitory concentration: 3100 nM
Beside the measured number, compound 4's estimate is 2.3-fold (0.35 log units) above it; measured number inside the range.
By their numbers in this assay, from the lowest: compounds 1, 4, 2 and 3 (each within the scatter of the next, the first and the last beyond it).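

Notes on the substituent on the oxygen on an aromatic ring: in this assay, replacing isopropyl with 2-hydroxyethyl gives a 3.4-fold lower number from compound 3 to compound 4 (0.53 log units; beyond the scatter), a modest step, so a change at this place can clear the scatter, which the only earlier step here, a 2.0-fold higher number from compound 2 to compound 3 (0.30 log units; within the scatter), did not do. The hydroxyl alone cannot be credited with this, since hydroxy in place of methyl on the saturated chain carbon gives a 1.7-fold lower number from compound 2 to compound 4 (0.22 log units; within the scatter), leaving compound 2 and compound 4 unresolved; the step beyond the scatter appears only against isopropyl, not against propyl. Nothing available gives a reason for either step.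

Open, going by these compounds, is whether the hydroxyl matters at all at this oxygen, which a longer chain ending in hydroxyl, or a methoxyethyl chain with that hydroxyl capped, would test against compound 4. Also open, on these data alone, is whether an amine or a carboxylic acid at the end of the same chain would reach beyond the scatter from compound 4, and whether a plain methoxy would stay with compound 2.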